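Swapping the pyridine on the amide for a methylphenyl

A few compounds are considered here, and "the series" means these few. Any claim that something is new, unique, unknown or untested is made for them only; others in the source may bear on it.

The compounds measured so far, all in a functional assay on SK-BR-3 cells (Homo sapiens) for antiproliferative activity, read by MTT assay, with a stated time of 72 h; on this read-out lower numbers stand for stronger inhibition and higher numbers for weaker inhibition:

Compound 1, `CCN1CCN(c2cc(C)c3cc(NC(=O)c4ccccc4C)ccc3n2)CC1`, gives 29200 nM.
Compound 3, `CCN1CCN(c2cc(C)c3cc(NC(=O)c4cccnc4)ccc3n2)CC1`, gives 10600 nM.
Compound 2, `Cc1cc(N(C)C)nc2ccc(NC(=O)c3ccc(Cl)c(Cl)c3)cc12`, gives only a limit of the assay, > 50000 nM.

Among the values that are actual numbers, compound 3 stands lowest, and its nearest neighbour compound 1 sits well apart from it: the step of a 2.8-fold lower number from compound 1 to compound 3 (0.44 log units; beyond the scatter) goes beyond the usual scatter and shows that pyridin-3-yl on the carbonyl carbon gives a lower number than 2-methylphenyl does. Compound 2 adds no number, only the limit noted in the limit of > 50000 nM in this assay, at which 1 of the 3 values shown sits.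

Compound 4, `CCN1CCN(c2cc(C)c3cc(NC(=O)c4ccc(C)cc4)ccc3n2)CC1`, is the next compound to be measured. It differs from compound 3 in one place: 4-methylphenyl in place of pyridin-3-yl on a carbonyl carbon. Among the measured compounds shown here, the only measured step that bears on this change is the one from compound 1 to compound 3, which moved from a methylphenyl to the pyridinyl and lowered the number. Going back from pyridin-3-yl to a methylphenyl, now with the methyl at another position, would be expected to reverse part of that gain, so the step of a 2.4-fold higher number from compound 3 to compound 4 (0.37 log units; beyond the scatter) is expected to point towards a higher number. Compound 4 is therefore estimated at 25000 nM, with a range from 8000 nM to 60000 nM.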

Compound 4, half-maximal inhibitory concentration: 11400 nM
Compound 4: middle estimate off by 2.2-fold (0.34 log units), on the high side, within the range that was stated.
By their numbers in this assay, from the lowest: compounds 3 and 4 (each within the scatter of the next); then compound 1. At a limit, above all of these: compound 2.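

The 4-methylphenyl group proves as good as the pyridin-3-yl group in this assay, with a 1.1-fold higher number from compound 3 to compound 4 (0.03 log units; within the scatter), so the ring nitrogen of compound 3 is not needed to reach this level, and an all-carbon ring on the carbonyl carbon serves equally well. The picture of the earlier step therefore changes: the higher number of compound 1 no longer reads as the price of losing the pyridine, since a 2.6-fold lower number from compound 1 to compound 4 (0.41 log units; beyond the scatter) shows that two methylphenyl amides can differ from each other, with only the place of the methyl group changed. The evidence at hand does not bear on what lies behind either step.

On these data alone, three aromatic groups at this position are too few to show a trend, and whether 3-methylphenyl would behave like 2-methylphenyl or like 4-methylphenyl stays unknown. Also open, as far as these compounds go, is whether the plain phenyl group, or a ring carrying an amine or a carboxylic acid in place of the methyl group, would keep the number where compound 3 and compound 4 stand or move it clearly in either direction.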